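The source may report more compounds than this note shows. Statements on the series, on what has been measured and on what is new or still open speak of the compounds shown alone.

In a physicochemical assay for acid dissociation, compound 1 (`CN(Cc1ccccc1)Cc1ccccc1CNc1ccnc2cc(Cl)ccc12`) gives 9.85. Going by the values given here, compound 2 (`CN(Cc1ccc(Cl)cc1)Cc1ccc(CNc2ccnc3cc(Cl)ccc23)cc1`) gives 9.74, so compound 1 stands level with the only other compound measured, the two numbers lying within the usual scatter of each other.

Compound 3 (`COc1ccc(CN(C)Cc2ccccc2CNc2ccnc3cc(Cl)ccc23)cc1`) has not yet been measured. It departs from compound 1 in one place, with methoxy in place of hydrogen on an aromatic carbon, para to a large group, so that a benzyl becomes a 4-methoxybenzyl (methoxy in place of hydrogen on an aromatic carbon).

Among the compounds with values here, no two measured compounds differ in one place only, so the data offer no direct precedent for this change. Within the data shown here, the one available guide is indirect: compound 1 and compound 2 differ in more than one place, and yet compound 2 gives 9.74, still within the scatter of compound 1. A small change is therefore expected in this assay, with no shift beyond the scatter in either direction. The estimated step of a number 0.05 log units higher from compound 1 to compound 3 (within the scatter) is expected to stay within that scatter. For compound 3 the estimated value is 9.9, with an expected range of 9.55 to 10.2.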

Compound 3, acid dissociation constant: 9.85
Compound 3: the middle estimate sits 0.05 log units above what was measured; measured number inside the range.
By their numbers in this assay, from the lowest: compounds 2, 1 and 3 (each within the scatter of the next).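

In this assay, putting methoxy in place of hydrogen on an aromatic carbon, para to a large group, so that a benzyl becomes a 4-methoxybenzyl, gives no change at the digits printed from compound 1 to compound 3 (within the scatter). Going by these compounds alone, this is the first comparison that isolates a single change, which the earlier pair, differing in more than one place, could not offer: at this position, the read-out is insensitive to this one replacement of hydrogen by methoxy. Nothing available accounts for this result, so it stands as an observation without an explanation.

The compounds shown cover only hydrogen and methoxy at this position, so it remains open whether a different group there, such as an amine, a carboxylic acid or a longer alkoxy chain, would also leave the number within the scatter. Going by these compounds, it also remains open whether methoxy would give the same outcome at another place on this ring or on a different part of the molecule.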